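Amine end of the series: ethylamino to isopropylamino

This account rests on a few compounds, and the source may have more. Where it says the series, first, only, none or still open, it means among the compounds named here.

Values measured in a functional assay on MCF7 cells (Homo sapiens) for antiproliferative activity (on this read-out lower numbers stand for stronger inhibition and higher numbers for weaker inhibition), are these
compound 1 `CC(=O)Oc1ccc(C(=O)Nc2cc3ccc(OCCC4CCCCN4)c(C)c3oc2=O)cc1CC=C(C)C` gives 710 nM
compound 2 `CC(C)=CCc1cc(C(=O)Nc2cc3ccc(OCCCN4CCCCC4)c(C)c3oc2=O)ccc1O` gives > 50000 nM as a limit of the assay, not a number
compound 3 `CCNCCCOc1ccc2cc(NC(=O)c3ccc(O)c(CC=C(C)C)c3)c(=O)oc2c1C` gives 980 nM

Of the two true numbers, compound 3 (980 nM) and compound 1 (710 nM) lie within the scatter of each other.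

Compound 4 `CC(C)=CCc1cc(C(=O)Nc2cc3ccc(OCCCNC(C)C)c(C)c3oc2=O)ccc1O` carries methyl in place of hydrogen on a saturated chain carbon bound to an amine nitrogen and a saturated chain carbon, so the ethylamino of compound 3 becomes isopropylamino (methyl in place of hydrogen on a saturated chain carbon bound to an amine nitrogen and a saturated chain carbon).

Among the measured compounds shown here, one measured step touches this amine end, and it is large and beyond the scatter (an at least 51-fold lower number from compound 2 to compound 3 (1.70 log units; beyond the scatter)). For compound 2 that step rests on a limit (the limit of > 50000 nM in this assay, at which 1 of the 3 values shown sits). That step exchanged piperidin-1-yl for ethylamino, while the present change adds one methyl and no ring. A far smaller move is therefore expected in this assay, probably toward a slightly higher number and not beyond the scatter. The expected step is a 1.3-fold higher number from compound 3 to compound 4 (0.12 log units; within the scatter) and no more than a modest shift is estimated. The large step still argues for a wide range. The estimate for compound 4 is 1300 nM within an expected range from 400 nM to 6000 nM with more room on the high side.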

Compound 4, half-maximal inhibitory concentration: 740 nM
Compound 4: the middle estimate sits 1.8-fold (0.24 log units) above what was measured; the range from low to high includes it.
By their numbers in this assay, from the lowest: compounds 1, 4 and 3 (each within the scatter of the next). At a limit, above all of these: compound 2.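

In this assay, the added methyl gives a 1.3-fold lower number from compound 3 to compound 4 (0.12 log units; within the scatter), so at this amine end ethylamino and isopropylamino are not told apart, and the extra branch on the saturated chain carbon bound to the amine nitrogen leaves the read-out within the scatter. With isopropylamino in place of piperidin-1-yl the result is an at least 67-fold lower number from compound 2 to compound 4 (1.82 log units; beyond the scatter), so the large step first seen with ethylamino now holds for a second amine, and in both comparisons the piperidin-1-yl compound is the one that stands apart. The size of both steps stays open-ended, as the value of compound 2 is a limit and not a number: the limit of > 50000 nM in this assay, at which 1 of the 4 values shown sits.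

The compounds shown leave open how far the amine end can grow before the read-out moves, as a tert-butylamino or cyclopentylamino end would test, and whether the ring of piperidin-1-yl or the full substitution of its nitrogen goes with the large step, which a diethylamino end set against a pyrrolidin-1-yl end would help separate. Also open, on these data alone, is whether either amine holds its place on a longer chain.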